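A few compounds are considered here, and "the series" means these few. Any claim that something is new, unique, unknown or untested is made for them only; others in the source may bear on it.

Compound 1 `CCC(=O)Nc1cc(C(=O)NC2CCCCC2)ccc1OC` gives the largest of the three numbers shown in an ADME assay on MDCK cells (Canis lupus familiaris) for cytotoxicity, read by cytopathic effect, with a stated time of 48 h; on this read-out higher numbers stand for lower toxicity in this test and lower numbers for higher toxicity in this test: compound 1 gives 510 uM. Compound 3 `COc1ccc(C(=O)Nc2ccccc2)cc1NC(=O)C1CCCC1` stands nearest, as compound 3 gives 459 uM in this assay, a gap within the scatter, while compound 2 `COc1ccc(C(=O)Nc2ccccc2)cc1NC(=O)c1ccccc1` gives 193 uM, a gap beyond the scatter. Compound 4 `CCC(=O)Nc1cc(C(=O)Nc2ccccn2)ccc1OC` has not yet been measured; it differs from compound 1 by pyridin-2-yl in place of cyclohexyl on an amide-type nitrogen. Among the compounds with values here, no measured step changes the group on the amide-type nitrogen. Within the data shown here, the only step available is a 2.4-fold higher number from compound 2 to compound 3 (0.38 log units; beyond the scatter), where a non-aromatic ring entered for an aromatic one on a carbonyl carbon; the change from compound 1 to compound 4 runs the other way, an aromatic ring entering for a non-aromatic one, and sits at a different place. The writer therefore expects a modest step to a lower number, a 1.7-fold lower number from compound 1 to compound 4 (0.23 log units; within the scatter), while treating the read-across as loose. The writer estimates that compound 4 will give 300 uM in this assay, with a range from 150 uM to 600 uM.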

Compound 4, half-maximal toxic concentration: > 668 uM
Compound 4 ended at the assay's limit (the forecaster's own chance of this, stated with the estimate: 5%); middle value at least 2.2-fold (0.34 log units) away from the limit.
By their numbers in this assay, from the lowest: compound 2; then compounds 3 and 1 (each within the scatter of the next). At a limit, above all of these: compound 4.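

Pyridin-2-yl in place of cyclohexyl on the amide-type nitrogen gives an at least 1.3-fold higher number from compound 1 to compound 4 (0.11 log units; that floor lies within the scatter), the first step read at this place. In this assay compound 4 gives > 668 uM, which is a limit of the assay and not a number: the limit of > 668 uM in this assay, at which 1 of the 4 values shown sits. An aromatic ring on this nitrogen thus brought no lower number, so the direction of a 2.4-fold higher number from compound 2 to compound 3 (0.38 log units; beyond the scatter), read on a carbonyl carbon, did not carry over to this place, although the floor of the new step lies within the scatter.

On these data alone, how far compound 4 stands from compound 1 remains open, since its value is only a limit. As far as these compounds go, whether the ring nitrogen or the aromatic ring matters also remains open, and a pyridin-3-yl or piperidin-1-yl group at this place would bear on that.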